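The compounds below may be only part of what the source reports. "The series", "measured", "known", "first", "only" and "open" are said of these compounds alone.

The measured compounds and their results in an ADME assay on a cell-free system (plasma, Mus musculus); a lower number here means a smaller unbound share, a higher number a larger unbound share of the compound:
Compound 1, `CCCS(=O)(=O)c1cccc(C#Cc2cc(Cl)ccc2OCC(=O)O)c1`, gives 0.024.
Compound 2, `CC(C)S(=O)(=O)c1ccc(Cl)c(C#Cc2cc(Cl)ccc2OCC(=O)O)c1`, gives "not determined" (no result reported).
Compound 3, `CCCS(=O)(=O)c1ccc(F)c(C#Cc2cc(Cl)ccc2OCC(=O)O)c1`, gives 0.007.

Among the two compounds that have a number, compound 3 stands lowest; the only measured step, a 3.4-fold lower number from compound 1 to compound 3 (0.54 log units; beyond the scatter), separates it from compound 1, and compound 2 reports no number at all. Compound 4, `CS(=O)(=O)c1ccc(F)c(C#Cc2cc(Cl)ccc2OCC(=O)O)c1`, has not yet been measured. It differs from compound 3 in a single place: hydrogen in place of ethyl on a saturated chain carbon bound to a sulfonyl sulfur. Among the measured compounds shown here, none of the measured steps touches this part of the molecule. For the measured compounds named here, the one step on record concerns fluoro in place of hydrogen on an aromatic carbon, a change elsewhere in the structure, so it says nothing direct about going from propylsulfonyl to methylsulfonyl. Going by the values given here, with no comparable step to lean on, only a small shift is expected for compound 4, and the step of a 1.7-fold higher number from compound 3 to compound 4 (0.23 log units; within the scatter) is expected to stay within the usual scatter around compound 3. Compound 4 is therefore estimated at 0.012, with a range from 0.005 to 0.03.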

Compound 4, unbound fraction: 0.054
For compound 4 the middle estimate is 4.5-fold (0.65 log units) below the measured one; the whole stated range lies below it.
By their numbers in this assay, from the lowest: compound 3; then compound 1; then compound 4.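

In this assay, among the compounds shown here, cutting propylsulfonyl back to methylsulfonyl gives a 7.7-fold higher number from compound 3 to compound 4 (0.89 log units; beyond the scatter), which shows that the saturated chain on the sulfonyl sulfur, a part of the molecule no earlier step touched, is a place where this read-out responds clearly. This step is also larger than the only earlier one, a 3.4-fold lower number from compound 1 to compound 3 (0.54 log units; beyond the scatter), and it runs the opposite way, so a change at the chain can more than offset the drop seen with the fluoro change on the aromatic carbon. The compounds carry no measurement that accounts for this shift.

As far as these compounds go, with the fluoro in place, only the two ends of this short series have numbers, so it remains open whether an ethyl group on the sulfonyl sulfur would land between them, or whether the response runs smoothly with chain length at all. From the compounds shown here alone, it is equally open how a longer chain, or a chain ending in an amine or a hydroxyl group, would behave, and whether the same shortening would give a step of similar size on a core without the fluoro.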